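Shrinking the amide ring on a proline-derived compound in a dipeptidyl peptidase 4 read-out

This account rests on a few compounds, and the source may have more. Where it says the series, first, only, none or still open, it means among the compounds named here.

Measured compounds:
compound 1, `N#C[C@@H]1CCCN1C(=O)[C@@H]1C[C@H](C(=O)N2CCCCCCC2)CN1`, 63%
compound 2, `CCN(CC)C(=O)[C@@H]1CN[C@H](C(=O)N2CCC[C@H]2C#N)C1`, 43%

In an assay on the whole organism (plasma, strain Sprague-Dawley) for inhibition of Dipeptidyl peptidase 4 (Rattus norvegicus), with a stated time of 6 h, at a dose of 1 mg/kg by the oral route (on this read-out lower numbers stand for less inhibition and higher numbers for more inhibition at the one dose given (going by the name of the read-out)), compound 1 gives the higher of the two numbers, with compound 2 standing a number 20 percentage points lower from compound 1 to compound 2 (beyond the scatter). Compound 3, `N#C[C@@H]1CCCN1C(=O)[C@@H]1C[C@H](C(=O)N2CCC2)CN1`, is not yet measured. It differs from compound 1 in one place: a group of 4 heavy atoms (3 carbon, 1 nitrogen; one four-membered non-aromatic ring with 1 hetero atom) in place of a group of 8 heavy atoms (7 carbon, 1 nitrogen; one eight-membered non-aromatic ring with 1 hetero atom), on a carbonyl carbon. Within the data shown here, the only step that bears on this is the one from compound 1 to compound 2, where a smaller group on the same carbonyl carbon gave a modest drop. A comparably small ring is expected to give a step of a number 23 percentage points lower from compound 1 to compound 3 (beyond the scatter) in this assay. Compound 3 is therefore estimated at 40%, with a range from 20% to 60%.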

Compound 3, a percentage reported as inhibition, in the whole organism at one dose (the size of the read-out at that dose, not a potency): 77%
Compound 3: middle estimate off by 37 percentage points, on the low side; measured number above the stated range.
By their numbers in this assay, from the lowest: compound 2; then compound 1; then compound 3.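

In this assay azetidin-1-yl on this carbonyl carbon gives a number 14 percentage points higher from compound 1 to compound 3 (beyond the scatter) and so shows that a smaller group here need not lose inhibition, unlike diethylamino in compound 2. Between the two small groups, a ring and an open chain, the result is a number 34 percentage points higher from compound 2 to compound 3 (beyond the scatter) and so the count of heavy atoms alone does not set the order of these compounds. Nothing available here accounts for this difference. The compounds shown leave open where rings of intermediate size, such as piperidin-1-yl or morpholin-4-yl, would fall.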